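Hydrazone series: removing the nitro from compound 2

The source may report more compounds than this note shows. Statements on the series, on what has been measured and on what is new or still open speak of the compounds shown alone.

Among the compounds with values here, compound 2 `O=c1cc(/C=N\Nc2ccc([N+](=O)[O-])cc2)c2c(OCc3ccccc3)cc(OCc3ccccc3)cc2o1` carries the hydrazone with a nitro on the aryl ring and is the only member of the series with a numerical read-out. In a functional assay, read by spectrophotometry, with a stated time of 1 h (a lower number here means a stronger inhibitor, a higher number a weaker inhibitor), compound 2 gives 97900 nM, a weak result. Compound 1 `O=c1cc(/C=N\O)c2c(OCc3ccccc3)cc(OCc3ccccc3)cc2o1`, the oxime, is recorded in this assay as "not active" (no number reported), so no numerical comparison between compound 1 and compound 2 is possible; the two entries show only that the oxime gave nothing measurable while the nitroaryl hydrazone gave a weak number.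

Compound 3 `O=c1cc(/C=N\Nc2ccccc2)c2c(OCc3ccccc3)cc(OCc3ccccc3)cc2o1` differs from compound 2 in one place: hydrogen in place of nitro on an aromatic carbon. Within the data shown here, no step between measured compounds covers this change, so the direction cannot be read from a measured pair. With compound 1 recorded as "not active" (no number reported) and compound 2 at 97900 nM, the series as a whole sits at the weak end, and the expectation for compound 3 is a step of a 1.5-fold higher number from compound 2 to compound 3 (0.19 log units; within the scatter), toward weaker inhibition or no reportable number, rather than a gain. Compound 3 is therefore expected to give 150000 nM, within a range from 50000 nM to 500000 nM.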

Compound 3, half-maximal inhibitory concentration: 401000 nM
Estimate against measurement, compound 3: 2.7-fold (0.43 log units) below, within the range that was stated.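

In this assay, hydrogen in place of nitro on the aromatic carbon gives a 4.1-fold higher number from compound 2 to compound 3 (0.61 log units; beyond the scatter), so this position responds to the change by more than the usual scatter, and the 4-nitrophenyl hydrazone is the stronger of the pair. Compound 3 still gives a number without the nitro, so a numerical read-out in the hydrazone series does not depend on that group, although both values remain at the weak end. Nothing shown accounts for the size or direction of this step.

Going by these compounds, one pair cannot show whether the read-out at this position follows a trend, and it remains open whether an amine, a methoxy group or a carboxylic acid in place of the nitro would fall with compound 2, with compound 3 or outside both. Steps involving compound 1 cannot be read, as it has no number, so the relation between the oxime and the aryl hydrazones also remains open.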